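This account rests on a few compounds, and the source may have more. Where it says the series, first, only, none or still open, it means among the compounds named here.

Working notes on the series in a functional assay on SK-OV-3 cells (Homo sapiens) for cytotoxicity, read by MTT assay, with a stated time of 3 days; a higher number here means a weaker inhibitor, a lower number a stronger inhibitor: compound 1 `N#Cc1c(O)nc(SCc2nc3ccccc3[nH]2)nc1-c1ccccc1` gives 2.55 nM, compound 2 `N#Cc1c(Nc2ccccc2)nc(SCc2nc3ccccc3[nH]2)nc1-c1ccccc1` gives 4.46 nM and compound 3 `CNc1nc(SCc2nc3ccccc3[nH]2)nc(-c2ccccc2)c1C#N` gives 3 nM here. Compound 3 stands level with both others, since its gap to each lies within the scatter and no order can be read among the three.

The next step leads to compound 4 `N#Cc1c(NC(N)=S)nc(SCc2nc3ccccc3[nH]2)nc1-c1ccccc1`, where a group with no common name replaces the methyl of compound 3, on a nitrogen on an aromatic ring: a group of 3 heavy atoms (1 carbon, 1 nitrogen, 1 sulfur; no ring) in place of one carbon atom, on a nitrogen on an aromatic ring.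

Three measured steps change the group at this same site: a 1.7-fold higher number from compound 1 to compound 2 (0.24 log units; within the scatter), then a 1.2-fold higher number from compound 1 to compound 3 (0.07 log units; within the scatter), and a 1.5-fold lower number from compound 2 to compound 3 (0.17 log units; within the scatter). All three stay within the scatter, across hydroxy, methylamino and anilino. Among the compounds with values here, none of the measured compounds carries the entering group, so these steps bear on the change only indirectly and the range is kept wide.

With compound 3 at 3 nM as the starting point, no shift beyond the scatter is expected in this assay, in either direction. The estimated step is no change at the digits printed from compound 3 to compound 4 (within the scatter) as the expected outcome. For compound 4 the expected value is 3 nM, with an estimated range from 1.2 nM to 8 nM as its bounds.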

Compound 4, half-maximal inhibitory concentration: 7.81 nM
The estimate for compound 4 lay 2.6-fold (0.42 log units) below the measured number; the measured number falls inside the stated range.
By their numbers in this assay, from the lowest: compounds 1, 3, 2 and 4 (each within the scatter of the next, the first and the last beyond it).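

In this assay this site now gives steps beyond the scatter, which none of the hydroxy, methylamino and anilino compounds gave among themselves: the group of 3 heavy atoms (1 carbon, 1 nitrogen, 1 sulfur; no ring) on a nitrogen on an aromatic ring gives a modest shift against the methyl (a 2.6-fold higher number from compound 3 to compound 4 (0.42 log units; beyond the scatter)) and against the hydroxy of the parent (a 3.1-fold higher number from compound 1 to compound 4 (0.49 log units; beyond the scatter)). The anilino compound still cannot be separated from the newcomer (a 1.8-fold higher number from compound 2 to compound 4 (0.24 log units; within the scatter)), so the site tolerates change only up to a point, and compound 4 cannot be called the weakest of the four. No measurement in hand accounts for the shift, and the step stands as an observation only.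

The compounds shown hold no urea group, with oxygen in place of the sulfur, and no unsubstituted amine at this site, so it stays open whether the shift goes with the sulfur or with the larger group as a whole. Going by these compounds, whether a longer chain such as propylamino would follow the methylamino or the entering group also stays open.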